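Swapping a Piperazine for a Succinimide on an Oxazolidinone

This account rests on a few compounds, and the source may have more. Where it says the series, first, only, none or still open, it means among the compounds named here.

Measured so far:
compound 1, `CCN1CCN(C[C@H]2CN(c3ccc(-n4cc(-c5ccccn5)cn4)c(F)c3)C(=O)O2)CC1`: 2.19
compound 2, `O=C1O[C@@H](CN2CCC(c3ccc(F)cc3)CC2)CN1c1ccc(-n2cc(-c3ccccn3)cn2)c(F)c1`: 5.78

In a physicochemical assay for lipophilicity, read by HPLC, measured as octanol-water partition (on this read-out higher numbers stand for higher lipophilicity and lower numbers for lower lipophilicity), compound 1 gives the lower of the two numbers shown, and compound 2 stands well apart from it, beyond the usual scatter. Compound 3, `O=C1CCC(=O)N1C[C@H]1CN(c2ccc(-n3cc(-c4ccccn4)cn3)c(F)c2)C(=O)O1`, is not yet measured. It differs from compound 1 in one place: 2,5-dioxopyrrolidin-1-yl in place of 4-ethylpiperazin-1-yl on a saturated chain carbon bound to a saturated ring carbon. For the measured compounds named here, no measured pair shows this exact change, so the expectation rests on the two values alone. A modest upward step is expected in this assay, a number 0.51 log units higher from compound 1 to compound 3 (beyond the scatter), staying far from compound 2. Compound 3 is therefore estimated at 2.7, within the range 2.1 to 3.4.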

Compound 3, partition coefficient: 1.58
Beside the measured number, compound 3's estimate is 1.12 log units above it, outside the stated range (below it).
By their numbers in this assay, from the lowest: compound 3; then compound 1; then compound 2.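

In this assay, putting 2,5-dioxopyrrolidin-1-yl in place of 4-ethylpiperazin-1-yl on a saturated chain carbon bound to a saturated ring carbon gives a number 0.61 log units lower from compound 1 to compound 3 (beyond the scatter). So the read-out at this position responds to this swap even though the two groups carry the same counts of hydrogen-bond donors and acceptors. No supporting measurement accounts for the direction of this step. Still open, as far as these compounds go, is where a morpholine, a primary amine or a carboxylic acid at this position would fall, and whether the same swap gives a similar step on another core.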